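A few compounds are considered here, and "the series" means these few. Any claim that something is new, unique, unknown or untested is made for them only; others in the source may bear on it.

Measured compounds:
Compound 1 `C=CC[C@@H]1C[C@]2([C@@H](C)Cc3ccc(OC)c(OC)c3)OCOC2=CC1=O`. In a functional assay on NCI-H460 cells (Homo sapiens) for antiproliferative activity, with a stated time of 72 h (a higher number here means a weaker inhibitor, a lower number a stronger inhibitor), compound 1 reaches only the assay limit, > 4000 nM.
Compound 2 `C=CC[C@H]1C[C@]2([C@@H](C)Cc3ccc(OC)c(C)c3)OCOC2=CC1=O`. In this assay compound 2 gives 630 nM.
Compound 3 `C=CC[C@H]1C[C@]2([C@@H](C)Cc3ccc(OC)c(C(=O)NC)c3)OCOC2=CC1=O`. In this assay compound 3 gives 1100 nM.

Of the two real numbers in this assay, compound 3 stands together with compound 2, separated by a 1.7-fold higher number from compound 2 to compound 3 (0.24 log units; within the scatter), a gap within the scatter, so the two are not distinguished. The value of compound 1 is a limit only the limit of > 4000 nM in this assay, at which 1 of the 3 values shown sits, and gives no number to rank against.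

Compound 4 `C=CC[C@H]1C[C@]2([C@@H](C)Cc3ccc(OC)c(Cl)c3)OCOC2=CC1=O` differs from compound 3 by chloro in place of methylcarbamoyl on an aromatic carbon. Within the data shown here, the one measured step at this position is a 1.7-fold higher number from compound 2 to compound 3 (0.24 log units; within the scatter), within the scatter. Among the measured compounds shown here, no measured step brings in chloro anywhere, so the effect of chloro itself is unknown here. With methyl and methylcarbamoyl at this position giving numbers within the scatter of each other, the expectation for compound 4 is a number near both, and a 1.5-fold lower number from compound 3 to compound 4 (0.17 log units; within the scatter) is expected to remain small. For compound 4 the estimate in this assay is 750 nM, with a range from 250 nM to 2500 nM.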

Compound 4, half-maximal inhibitory concentration: 640 nM
Beside the measured number, compound 4's estimate is 1.2-fold (0.07 log units) above it, within the range that was stated.
By their numbers in this assay, from the lowest: compounds 2, 4 and 3 (each within the scatter of the next). At a limit, above all of these: compound 1.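

In this assay, replacing methylcarbamoyl with chloro (a 1.7-fold lower number from compound 3 to compound 4 (0.24 log units; within the scatter)) and replacing methyl with chloro (a 1.0-fold higher number from compound 2 to compound 4 (0.01 log units; within the scatter)) both stay within the scatter, so chloro cannot be told apart from either earlier group at this position, ortho to a methoxy group. The hydrogen-bond donor and acceptor of methylcarbamoyl are absent from chloro, yet the numbers of compound 3 and compound 4 are not distinguished, which holds for this pair only. Nothing measured here gives a cause for this lack of separation.

On these data alone, whether an amine, a carboxylic acid or a longer chain at this position would also stay within the scatter remains open. Compound 1 gives only a limit, > 4000 nM, and differs from these compounds in more than one place, so it adds nothing on this position.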